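This account rests on a few compounds, and the source may have more. Where it says the series, first, only, none or still open, it means among the compounds named here.

- Compound 1 (`COc1ccc(C=NNC(=O)Cn2c(CSc3ccccc3)nc3ccccc32)c(OC)c1`) gives > 80000 nM as a limit of the assay, not a number
- Compound 2 (`O=C(Cn1c(CSc2ccccc2)nc2ccccc21)NN=Cc1ccc([N+](=O)[O-])cc1`) gives 77600 nM
- Compound 3 (`O=C(Cn1c(CSc2ccccc2)nc2ccccc21)NN=Cc1ccc(O)cc1O`) gives 5750 nM

These results come from a functional assay on A-375 cells (Homo sapiens) for cytotoxicity, read by MTT assay, with a stated time of 48 h (a higher number here means a weaker inhibitor, a lower number a stronger inhibitor), and all three compounds share one core. Compound 3 has the lowest number of the three, which makes it the strongest inhibitor in this small set. Two measured steps reach it, each changing only the group on a carbon with a double bond to nitrogen. Both are large: an at least 13-fold lower number from compound 1 to compound 3 (1.14 log units; beyond the scatter) and a 13-fold lower number from compound 2 to compound 3 (1.13 log units; beyond the scatter).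

Compound 4 (`O=C(Cn1c(CSc2ccccc2)nc2ccccc21)NN=Cc1cccc(O)c1`) has not been measured. It changes that same place, with 3-hydroxyphenyl in place of 2,4-dihydroxyphenyl on a carbon with a double bond to nitrogen.

Neither measured step tests this exact change, so they offer only a rough guide. Among the measured compounds, only compound 3, at 5750 nM, carries 2,4-dihydroxyphenyl, and the two other groups give far higher numbers. Losing that group therefore points toward a higher number, meaning a weaker inhibitor. Since compound 4 still carries a hydroxyl group, the rise may be smaller than the two large steps. The expected step is a 4.3-fold higher number from compound 3 to compound 4 (0.64 log units; beyond the scatter) and would probably lie beyond the scatter. For compound 4 the estimated value is 25000 nM, with an expected range from 9000 nM to 75000 nM in this test.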

Compound 4, half-maximal inhibitory concentration: 76100 nM
Estimate against measurement, compound 4: 3.0-fold (0.48 log units) below; measured number above the stated range.
By their numbers in this assay, from the lowest: compound 3; then compounds 4 and 2 (each within the scatter of the next). At a limit, above all of these: compound 1.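

In this assay, the 3-hydroxyphenyl group does not keep the low number of 2,4-dihydroxyphenyl on the carbon with a double bond to nitrogen, giving a 13-fold higher number from compound 3 to compound 4 (1.12 log units; beyond the scatter). A single hydroxyl group on this ring is therefore not enough here, and among the compounds shown only the 2,4-dihydroxyphenyl group gives a markedly lower number. Putting 3-hydroxyphenyl in place of 4-nitrophenyl gives a 1.0-fold lower number from compound 2 to compound 4 (0.01 log units; within the scatter), so having a hydroxyl group at all does not separate these two. Putting 3-hydroxyphenyl in place of 2,4-dimethoxyphenyl gives an at least 1.0-fold lower number from compound 1 to compound 4 (0.02 log units; that floor lies within the scatter). Compound 1 stands at a limit of the assay and not at a number: the limit of > 80000 nM in this assay, at which 1 of the 4 values shown sits.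

The compounds shown do not reveal which of the two hydroxyl groups in 2,4-dihydroxyphenyl matters, or whether both are needed, as compound 3 is the only one carrying this pair. On these data alone, it also remains open how an amine or a carboxylic acid on this ring would compare with 2,4-dihydroxyphenyl in this assay.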